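The compounds below may be only part of what the source reports. "The series", "measured", "known", "first", "only" and "open" are said of these compounds alone.

In a functional assay on L1210 cells (Mus musculus) for inhibition, read by MTT assay (on this read-out higher numbers stand for weaker inhibition and lower numbers for stronger inhibition), the measured compounds are:

compound 1 `N#CC1CN1C(=O)Nc1ccc(Cl)c(Cl)c1`: 2600 nM
compound 2 `N#CC1CN1C(=O)Nc1ccc(F)cc1`: 7300 nM
compound 3 `N#CC1CN1C(=O)Nc1ccc(Cl)cc1Cl`: 207000 nM

All three share one core and differ only in the groups on the aromatic ring. Compound 2 stands second highest of these three numbers. Its nearest neighbour is compound 1, whose number is lower by a gap beyond the usual scatter; the furthest is compound 3, whose number is higher, again beyond the scatter. No two of the measured compounds differ in only one place, so no single step can be read off from them.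

Compound 4 `N#CC1CN1C(=O)Nc1ccc([N+](=O)[O-])cc1` has not yet been measured. It differs from compound 2 in one place: nitro in place of fluoro on an aromatic carbon. Within the data shown here, the measured set holds no nitro compound and no swap of one group for another at this place, so nothing among the three tells how large such a step is. The expected step is a 1.5-fold lower number from compound 2 to compound 4 (0.16 log units; within the scatter), small and of uncertain direction. Compound 4 is estimated at 5000 nM, within a range from 1500 nM to 20000 nM.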

Compound 4, half-maximal inhibitory concentration: 2600 nM
The estimate for compound 4 lay 1.9-fold (0.28 log units) above the measured number; the measured number falls inside the stated range.
By their numbers in this assay, from the lowest: compounds 1 and 4 (each within the scatter of the next); then compound 2; then compound 3.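

Within this assay, putting nitro in place of fluoro on the aromatic carbon gives a 2.8-fold lower number from compound 2 to compound 4 (0.45 log units; beyond the scatter), the first change in this set that can be read at a single place. The number moves towards stronger inhibition, so this place on the ring responds to the group it carries, and a group with more heavy atoms than fluoro does not cost inhibition here, though the step is only modest. The compounds shown offer no measurement that explains this step.

Among these compounds, two groups at one place give only a single step, so they show no trend across groups. From the compounds shown here alone, whether an amine, a methoxy group or a carboxylic acid at this same place would move the number further, or back the other way, remains open.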